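Two ureas and two amides on a shared core: growth inhibition

The compounds below may be only part of what the source reports. "The series", "measured", "known", "first", "only" and "open" are said of these compounds alone.

Measured compounds:
Compound 1, `O=C(Nc1cccc([N+](=O)[O-])c1)Nc1nc2ccc(Cl)cc2s1`: 1.03 ug/mL
Compound 2, `O=C(Nc1cccc([N+](=O)[O-])c1)Nc1nc2ccc(F)cc2s1`: 0.83 ug/mL
Compound 3, `COc1ccc(C(=O)Nc2nc3cc(C)cc(C)c3s2)cc1`: > 10 ug/mL

Among the measured compounds shown here, in a functional assay on NUGC-3 cells (Homo sapiens) for antiproliferative activity, read by sulforhodamine B assay (on this read-out lower numbers stand for stronger inhibition of growth and higher numbers for weaker inhibition of growth), compound 1 gives 1.03 ug/mL and compound 2 gives 0.83 ug/mL; between them stands the one measured step, a 1.2-fold lower number from compound 1 to compound 2 (0.09 log units; within the scatter). For compound 3 the assay returns no number, only a limit, as recorded in the limit of > 10 ug/mL in this assay, at which 1 of the 3 values shown sits. For the measured compounds named here, compound 3 thus stands apart from the two ureas: it is the one entry on this read-out that has no measured value, and it is the only amide with a value of any kind.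

Compound 4, `Cc1cc(C)c2sc(NC(=O)c3ccc(C#N)cc3)nc2c1`, differs from compound 3 by cyano in place of methoxy on an aromatic carbon. Going by the values given here, no measured step bears on this change: the single step in hand swaps halogens on the shared core of the ureas and says nothing about the group on the amide side. The expectation for compound 4 therefore rests on compound 3 alone, whose result is a limit, and the step of a number no higher from compound 3 to compound 4 (the limit leaves the size open) is expected to stay within the scatter of that starting point. Compound 4 is estimated at 10 ug/mL in this assay, with a range from 3 ug/mL to 30 ug/mL, and a limit rather than a number is the more likely report.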

Compound 4, concentration for 50% growth inhibition: 0.62 ug/mL
Estimate against measurement, compound 4: 16-fold (1.21 log units) above; measured number outside the range, below it.
By their numbers in this assay, from the lowest: compounds 4, 2 and 1 (each within the scatter of the next). At a limit, above all of these: compound 3.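

On the amide side of the series, the group para to a large group has a clear bearing on the read-out: in this assay, cyano in place of methoxy on an aromatic carbon gives an at least 16-fold lower number from compound 3 to compound 4 (1.20 log units; beyond the scatter). The only earlier step, a 1.2-fold lower number from compound 1 to compound 2 (0.09 log units; within the scatter), exchanged one halogen for another on the shared core of the ureas, so this pair is the first in the compounds shown to mark a place where a single change moves growth inhibition beyond the scatter, and it gives the amides their first measured number. The true size of the step cannot be read, and only its lower bound is known, because the starting point, compound 3, is a limit and not a number: the limit of > 10 ug/mL in this assay, at which 1 of the 4 values shown sits.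

Among the compounds shown here, the single pair leaves open whether the step belongs to cyano in particular or would also appear with other groups at this place, such as an amine, a carboxylic acid or a longer chain like ethoxy. It also leaves open whether the same exchange would carry the same weight on the ureas, or on an amide whose shared core bears chloro or fluoro.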